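The source may report more compounds than this note shows. Statements on the series, on what has been measured and on what is new or still open speak of the compounds shown alone.

Compound 1, `CN1C(=O)N(Cc2cc(C(F)(F)F)cc(C(F)(F)F)c2)C2(CCN(C(=O)c3cccc4ccccc34)CC2)C1=O`, in an assay on CHO cells for binding affinity to Substance-P receptor (Homo sapiens) (on this read-out lower numbers stand for stronger inhibition and higher numbers for weaker inhibition), compound 1 gives 457 nM.
Compound 2, `CN1C(=O)N(Cc2cc(C(F)(F)F)cc(C(F)(F)F)c2)C2(CCN(C(=O)c3c(Cl)cccc3Cl)CC2)C1=O`, in this assay compound 2 gives 646 nM.

Within the data shown here, of the two numbers so far, compound 2 has the higher one, but its only neighbour is compound 1, and the gap between them, a 1.4-fold higher number from compound 1 to compound 2 (0.15 log units; within the scatter), is no larger than the usual spread of repeated runs. So the two compounds cannot be told apart on these data.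

Compound 3, `CN1C(=O)N(Cc2cc(C(F)(F)F)cc(C(F)(F)F)c2)C2(CCN(C(=O)c3ccccc3F)CC2)C1=O`, is the next compound. It differs from compound 2 in one place: 2-fluorophenyl in place of 2,6-dichlorophenyl on a carbonyl carbon. Among the measured compounds shown here, the only measured step that touches the same carbonyl carbon is the one from compound 1 to compound 2, which swapped one aromatic group for another and moved the number by a 1.4-fold higher number from compound 1 to compound 2 (0.15 log units; within the scatter), inside the scatter. For the measured compounds named here, that is the sole guide here, and it points to a small effect of changing the aryl group at this position, though a single step is thin ground.

For compound 3 the expected change is therefore a 1.2-fold higher number from compound 2 to compound 3 (0.09 log units; within the scatter), a step not clearly beyond the scatter. The expected value for compound 3 in this assay is 800 nM, with an estimated range from 250 nM to 2500 nM.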

Compound 3, inhibition constant: 1480 nM
For compound 3 the middle estimate is 1.9-fold (0.27 log units) below the measured one; measured number inside the range.
By their numbers in this assay, from the lowest: compounds 1 and 2 (each within the scatter of the next); then compound 3.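

In this assay the group on this carbonyl carbon now proves able to move the number beyond the scatter: putting 2-fluorophenyl in place of 2,6-dichlorophenyl gives a 2.3-fold higher number from compound 2 to compound 3 (0.36 log units; beyond the scatter) and putting it in place of naphthalen-1-yl gives a 3.2-fold higher number from compound 1 to compound 3 (0.51 log units; beyond the scatter) while the earlier swap between those two larger groups stayed within the scatter. Both new steps are modest, but together they make compound 3 the weakest of the three, so the aryl groups at this position are not all interchangeable. Nothing available explains why this change raises the number.

The step from compound 2 to compound 3 changes two things at once, replacing two chlorine atoms with one fluorine atom, so the compounds shown cannot separate the kind of halogen from the number of halogens. A plain phenyl group with no halogen would help to separate those two changes, and a saturated cyclohexyl group on the same carbonyl carbon would ask whether an aromatic ring is needed there at all.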